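The source may report more compounds than this note shows. Statements on the series, on what has been measured and on what is new or still open speak of the compounds shown alone.

Two compounds share one core and differ only in the aryl ring hung from the carbon with a double bond to nitrogen. Compound 1 `Cc1ccc(S(=O)(=O)N2CC3(C[C@H]2C(=O)N/N=C/c2cccc([N+](=O)[O-])c2)SCCS3)cc1` carries a 3-nitrophenyl there, while compound 2 `Cc1ccc(S(=O)(=O)N2CC3(C[C@H]2C(=O)N/N=C/c2ccccc2[N+](=O)[O-])SCCS3)cc1` carries a 2-nitrophenyl. In a functional assay on C8166 cells (Homo sapiens) for cytotoxicity, read by MTT assay, with a stated time of 72 h (a higher number here means that more compound is tolerated, a lower number that less compound is tolerated), compound 1 sits at a limit of the assay and shows > 395000 nM with no number behind it. In this assay, for the measured compounds named here, compound 2 gives 65000 nM and is thus the only compound with an actual number among the two values shown. Going by the values given here, the move an at least 6.0-fold lower number from compound 1 to compound 2 (0.78 log units; beyond the scatter) is the one measured step.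

Compound 3 `Cc1ccc(S(=O)(=O)N2CC3(C[C@H]2C(=O)N/N=C/c2ccccc2Br)SCCS3)cc1` keeps the core of compound 2 and differs from it in one place: bromo in place of nitro on an aromatic carbon on an aromatic carbon of a six-membered aromatic ring of carbon only, ortho to a large group. Among the compounds with values here, the single measured step changes where the nitro sits and not what replaces it, so no measured step bears directly on this exchange. Without a guide, the expectation is a step of no change at the digits printed from compound 2 to compound 3 (within the scatter) that stays within the scatter. Compound 3 is therefore estimated in this assay at 65000 nM with a range from 20000 nM to 250000 nM.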

Compound 3, half-maximal cytotoxic concentration: 177000 nM
The estimate for compound 3 lay 2.7-fold (0.44 log units) below the measured number; the measured number falls inside the stated range.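

The earlier step moved the nitro to another place on the ring, while this one keeps the place and exchanges the group. In this assay that exchange gives a 2.7-fold higher number from compound 2 to compound 3 (0.44 log units; beyond the scatter), so the identity of the group on this aromatic carbon, and not only its place, shifts how much compound the cells tolerate. Compound 1 is known only through a limit of the assay: the limit of > 395000 nM in this assay, at which 1 of the 3 values shown sits. Measured against that limit, the comparison reads an at least 2.2-fold lower number from compound 1 to compound 3 (0.34 log units; beyond the scatter), a bound rather than an exact size, and it places compound 3 between the two nitro compounds, with compound 1 still the best tolerated of the three.

The compounds shown carry only nitro or bromo on this ring, so it stays open how a chloro, a methoxy or an amine on the same aromatic carbon would fare. From the compounds shown here alone, how bromo would fare where compound 1 carries its nitro also stays open.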